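Notes on 4-fluorobenzyl in place of 2-bromobenzyl

This account rests on a few compounds, and the source may have more. Where it says the series, first, only, none or still open, it means among the compounds named here.

Measured in a functional assay on BGC-823 cells (Homo sapiens) for inhibition, read by MTT assay, with a stated time of 72 h; a lower number here means a stronger inhibitor, a higher number a weaker inhibitor:
- compound 1 `Cc1cc(N2CC[C@@H](C)[C@@H](N(C)c3ncnc4[nH]ccc34)C2)n2nc(SCC3CC3)nc2n1`: 36500 nM
- compound 2 `Cc1cc(N2CC[C@@H](C)[C@@H](N(C)c3ncnc4[nH]ccc34)C2)n2nc(SCc3ccccc3Br)nc2n1`: 81100 nM

In this assay compound 2 stands highest of the two, at 81100 nM. Compound 3 `Cc1cc(N2CC[C@@H](C)[C@@H](N(C)c3ncnc4[nH]ccc34)C2)n2nc(SCc3ccc(F)cc3)nc2n1` differs from it as follows: 4-fluorophenyl in place of 2-bromophenyl on a saturated chain carbon bound to a sulfur. This is 4-fluorophenyl in place of 2-bromophenyl on a saturated chain carbon bound to a sulfur. Among the compounds with values here, the only measured step at this place, a 2.2-fold higher number from compound 1 to compound 2 (0.35 log units; beyond the scatter), is modest, and no measured compound carries 4-fluorophenyl. No step beyond the scatter is therefore expected in this assay, with a slight lean towards a lower number. The expected change is a 1.5-fold lower number from compound 2 to compound 3 (0.17 log units; within the scatter). For compound 3 the estimated value is 55000 nM, with an expected range of 22000 nM to 110000 nM.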

Compound 3, half-maximal inhibitory concentration: 44300 nM
Beside the measured number, compound 3's estimate is 1.2-fold (0.09 log units) above it; measured number inside the range.
By their numbers in this assay, from the lowest: compounds 1, 3 and 2 (each within the scatter of the next, the first and the last beyond it).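

In this assay, 4-fluorobenzyl in place of 2-bromobenzyl gives a 1.8-fold lower number from compound 2 to compound 3 (0.26 log units; within the scatter) and so does not register as a real change at this position. With a 1.2-fold higher number from compound 1 to compound 3 (0.08 log units; within the scatter) as well, compound 3 lies within the scatter of both neighbours, leaving the step from compound 1 to compound 2 as the only one beyond it. Nothing available explains these numbers.

As far as these compounds go, whether an amine, a carboxylic acid or a longer chain on this sulfur would shift the number remains open. So does the effect of changes elsewhere on the shared core.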